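Cytotoxicity notes: the step from compound 3 to compound 4

The source may hold more compounds than are shown below. What is called first, only, known or untested is meant among the compounds shown, and "the series" means these compounds.

Three compounds have been run in an ADME assay on Huh-7 cells (Homo sapiens) for cytotoxicity; on this read-out lower numbers stand for higher toxicity in this test and higher numbers for lower toxicity in this test. Compound 1 `O=C(NC(=S)N1CCc2cc(OCc3ccccc3)ccc21)c1ccccc1` gives 45200 nM. Compound 2 `O=C(NC(=S)N1CCc2cccc(OCc3ccccc3)c21)c1ccccc1` returns only a limit of the assay, > 50000 nM. Compound 3 `O=C(NC(=S)N1CCc2c(OCCCCCOc3ccc(Cl)cc3)cccc21)c1ccc(Cl)cc1` gives 21700 nM, the lowest of the two numbers obtained; its nearest neighbour is compound 1, whose number lies beyond the scatter above it. Of the three values, one sits at the limit of > 50000 nM in this assay, at which 1 of the 3 values shown sits, so the spread of the series is known only at its lower end.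

Compound 4 `CN(C)c1ccc(C(=O)NC(=S)N2CCc3c(OCCCCCOc4ccc(Cl)cc4)cccc32)cc1` has not been measured. It differs from compound 3 by dimethylamino in place of chloro on an aromatic carbon, in words: dimethylamino in place of chloro on an aromatic carbon. Within the data shown here, no two measured compounds differ in just this way, so no measured step sets the size. Among the measured compounds shown here, with every number so far lying within a narrow band near the top of the assay window, the step from compound 3 to compound 4 in this assay is expected at a 1.2-fold higher number from compound 3 to compound 4 (0.06 log units; within the scatter), none beyond the scatter. Compound 4 is accordingly estimated at 25000 nM in this assay, within a range from 11000 nM to 50000 nM.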

Compound 4, half-maximal cytotoxic concentration: > 50000 nM
Compound 4: only a limit was reported; the forecaster's own chance of this, stated with the estimate: 25%; middle value at least 2.0-fold (0.30 log units) from the limit.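

In this assay, the aromatic carbon para to a large group gives the series its first step between compounds that differ in one place, with 4-(dimethylamino)phenyl in place of 4-chlorophenyl: an at least 2.3-fold higher number from compound 3 to compound 4 (0.36 log units; beyond the scatter). Compound 4 returns only a limit of the assay, > 50000 nM, so this step has a lower bound but no known size. The change takes compound 4 to the top of the assay window, leaving more of the series there: the limit of > 50000 nM in this assay, at which 2 of the 4 values shown sit.

This single pair does not show whether the step is specific to dimethylamino or would also appear with a primary amine, a morpholine or a methoxy group at this place. Going by these compounds, whether the same change has a similar effect on a shorter side chain, such as the benzyloxy group of compound 1, also remains open.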